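A few compounds are considered here, and "the series" means these few. Any claim that something is new, unique, unknown or untested is made for them only; others in the source may bear on it.

Compound 1 `O=C(CSc1nnnn1-c1ccccc1)N/N=c1/scc(-c2ccc(F)cc2)n1-c1ccccc1` — 35.8%
Compound 2 `O=C(CSc1nnnn1-c1ccccc1)N/N=c1/scc(-c2ccc(Cl)cc2)n1-c1ccccc1` — 54.3%

Among the compounds with values here, in a functional assay on C6 cells (Rattus norvegicus) for cytotoxicity, read by MTT assay, with a stated time of 24 h, tested at 100 ug/mL (on this read-out higher numbers stand for a weaker effect at the one concentration tested and lower numbers for a stronger effect), compound 1 gives 35.8%, the lowest of the two numbers measured so far. Within the data shown here, compound 2 gives 54.3%, and the step of a number 18.5 percentage points higher from compound 1 to compound 2 (beyond the scatter) is the only measured change in this set. Among the measured compounds shown here, it concerns a substituent on an aromatic carbon of the shared core and has no counterpart in the change now considered.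

Compound 3 `O=C(CSc1ncccn1)N/N=c1/scc(-c2ccc(F)cc2)n1-c1ccccc1` differs from compound 1 in one place: pyrimidin-2-yl in place of 1-phenyl-1H-tetrazol-5-yl on a sulfur. The group that leaves and the group that enters sit on a sulfur whose other neighbour is a saturated chain carbon, far from the site altered between compound 1 and compound 2. For the measured compounds named here, no measured step therefore bears on this change, and its effect on this assay cannot be read from the data in either direction.

With nothing to lean on, the expected value for compound 3 is placed near that of compound 1, with a broad range: 45% (from 22% to 72%), which means an expected step of a number 9.2 percentage points higher from compound 1 to compound 3 (within the scatter).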

Compound 3, a percentage reported as activity, at one concentration (the size of the read-out at that concentration, not a potency): 53.4%
Estimate against measurement, compound 3: 8.4 percentage points below, within the range that was stated.
By their numbers in this assay, from the lowest: compound 1; then compounds 3 and 2 (each within the scatter of the next).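

In this assay, pyrimidin-2-yl in place of 1-phenyl-1H-tetrazol-5-yl on the sulfur gives a number 17.6 percentage points higher from compound 1 to compound 3 (beyond the scatter), so at the one concentration tested the effect is weaker with the smaller of these two groups. Within the data shown here, this is the first measured change at this place, and it shows that the substituent on the aromatic carbon is no longer the only site known to move the number. Nothing measured on these compounds accounts for the step.

The compounds shown leave open whether the lower number of compound 1 goes with the tetrazole ring or with the phenyl ring of the group that left, a question that a 1-methyl-1H-tetrazol-5-yl group on the sulfur could help to separate. They also leave open where a pyridin-2-yl group or a simple methyl on the sulfur would fall, and whether this change has a similar effect with chloro in place of fluoro on the aromatic carbon.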